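Carboxy to acetyl on the anilide of a chlorinated enone

The compounds below may be only part of what the source reports. "The series", "measured", "known", "first", "only" and "open" are said of these compounds alone.

Of the compounds shown here, three sharing one core have been measured in a functional assay on CLL cells (Homo sapiens) for cytotoxicity, read by MTT assay, with a stated time of 48 h; on this read-out higher numbers stand for an effect only at larger amounts of compound and lower numbers for an effect already at smaller amounts. Compound 1 `C=C(CC)C(=O)c1ccc(OCC(=O)NC2CCN(CC(=O)OC)CC2)c(Cl)c1Cl` carries a basic piperidine-linked ester and gives 10600 nM. Compound 2 `C=C(CC)C(=O)c1ccc(OCC(=O)Nc2ccc(C(=O)O)cc2)c(Cl)c1Cl` carries a 4-carboxyphenyl amide and gives 5000 nM. Compound 3 `C=C(CC)C(=O)c1ccc(OCC(=O)NC(CS)C(=O)OCC)c(Cl)c1Cl` carries a 1-(ethoxycarbonyl)-2-sulfanylethyl amide and gives 4800 nM. On these numbers compound 2 stands second highest of the three: its nearest neighbour is compound 3, separated by a 1.0-fold lower number from compound 2 to compound 3 (0.02 log units; within the scatter), which lies within the scatter, while compound 1 lies a larger distance above it, beyond the scatter.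

Compound 4 `C=C(CC)C(=O)c1ccc(OCC(=O)Nc2ccc(C(C)=O)cc2)c(Cl)c1Cl` differs from compound 2 by methyl in place of hydroxy on a carbonyl carbon. Within the data shown here, no measured step exchanges the carboxy group itself, so nothing directly bears on this change. Among the measured compounds shown here, the only step measured from compound 2, namely a 1.0-fold lower number from compound 2 to compound 3 (0.02 log units; within the scatter), replaces the whole amide substituent without moving the number beyond the scatter, and the spread of all three values in this assay is modest. The step from compound 2 to compound 4 in this assay is therefore expected to be small, at most a slight move to lower numbers, written as a 1.3-fold lower number from compound 2 to compound 4 (0.10 log units; within the scatter). Compound 4 is expected to give about 4000 nM in this assay, within a range from 1500 nM to 12000 nM.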

Compound 4, half-maximal effective concentration: 3900 nM
For compound 4 the middle estimate is 1.0-fold (0.01 log units) above the measured one, within the range that was stated.
By their numbers in this assay, from the lowest: compounds 4, 3 and 2 (each within the scatter of the next); then compound 1.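

In this assay, exchanging hydroxy for methyl on a carbonyl carbon takes away the hydrogen-bond donor of the carboxy group, and the result is a 1.3-fold lower number from compound 2 to compound 4 (0.11 log units; within the scatter), so on this read-out the donor can be lost without the number leaving the scatter. The earlier step replaced the whole amide substituent, whereas this one changes a single group on the 4-carboxyphenyl amide, and a 1.2-fold lower number from compound 3 to compound 4 (0.09 log units; within the scatter) shows that the 4-acetylphenyl amide also remains level with the 1-(ethoxycarbonyl)-2-sulfanylethyl amide. Nothing available explains why either exchange leaves the number within the scatter.

From the compounds shown here alone, it remains open whether an amine, a nitrile or a primary amide in place of the carboxy group of compound 2 would also stay within the scatter, or whether one of them would reach the distance that separates compound 1 from the others. Also open, going by these compounds, is whether a longer acyl chain in place of the acetyl group of compound 4, or a plain phenyl amide with no such group, would move the number in either direction.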